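The compounds below may be only part of what the source reports. "The series", "measured", "known", "first", "only" and "open" are said of these compounds alone.

Working notes on the series. Compound 3 `CCCCCN(CCCCC)C(=O)N1CCN(C(=O)N(c2ccccc2)c2cccc(OC)c2)[C@H](C(=O)O)C1` gives 7.8 nM in an assay for inhibition of Type-2 angiotensin II receptor (Rattus norvegicus) (a lower number here means a stronger inhibitor, a higher number a weaker inhibitor), the highest of the three numbers in hand. Compound 1 `CCCCCN(CCCCC)C(=O)N1CCN(C(=O)N(c2ccccc2)c2ccccc2)[C@H](C(=O)O)C1` gives 1.4 nM, and compound 2 `CCCCCN(CCCCC)C(=O)N1CCN(C(=O)N(c2ccccc2)c2cccc(C)c2)[C@H](C(=O)O)C1` gives 0.7 nM. The step of a 5.6-fold higher number from compound 1 to compound 3 (0.75 log units; beyond the scatter) and the step of an 11-fold higher number from compound 2 to compound 3 (1.05 log units; beyond the scatter) both concern the same aromatic ring that is altered next; the step of a 2.0-fold lower number from compound 1 to compound 2 (0.30 log units; within the scatter) on that ring stays within the scatter.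

Compound 4 `CCCCCN(CCCCC)C(=O)N1CCN(C(=O)N(c2ccccc2)c2ccc(C(=O)O)cc2)[C@H](C(=O)O)C1` carries 4-carboxyphenyl in place of 3-methoxyphenyl on an amide-type nitrogen. Among the compounds with values here, no measured step involves a carboxyphenyl group, so the change is only loosely anchored: the substitution steps already seen on this ring range from within the scatter to modest, and the carboxylic acid is a larger departure than either methyl or methoxy. The expectation for compound 4 is therefore a number near that of compound 3, with wide uncertainty in both directions, and the expected step is a 1.0-fold higher number from compound 3 to compound 4 (0.01 log units; within the scatter). The estimate for compound 4 in this assay is 8 nM, between 1.5 nM and 45 nM.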

Compound 4, half-maximal inhibitory concentration: 180 nM
The estimate for compound 4 lay 23-fold (1.35 log units) below the measured number; the measured number lies above the stated range.
By their numbers in this assay, from the lowest: compounds 2 and 1 (each within the scatter of the next); then compound 3; then compound 4.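

In this assay, this ring on the amide-type nitrogen proves far less tolerant of a carboxy group than the earlier substituents suggested: a 130-fold higher number from compound 1 to compound 4 (2.11 log units; beyond the scatter) exceeds both a 2.0-fold lower number from compound 1 to compound 2 (0.30 log units; within the scatter) and a 5.6-fold higher number from compound 1 to compound 3 (0.75 log units; beyond the scatter). The step is also large when read from the substituted rings, with a 23-fold higher number from compound 3 to compound 4 (1.36 log units; beyond the scatter) and a 260-fold higher number from compound 2 to compound 4 (2.41 log units; beyond the scatter), so compound 4 stands well apart from all three earlier compounds. No measured evidence available here bears on the origin of this drop.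

Since 4-carboxyphenyl differs from 3-methoxyphenyl and 3-methylphenyl in both the group and its ring position, the compounds shown do not separate these two contributions. Going by these compounds, whether the higher number belongs to the carboxylic acid itself also stays open, and a methyl ester or a primary amide in its place would address that.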